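This account rests on a few compounds, and the source may have more. Where it says the series, first, only, none or still open, it means among the compounds named here.

The measured compounds in an assay on isolated protein (strain Sprague-Dawley) for inhibition of Amine oxidase [flavin-containing] B (Rattus norvegicus), read by spectrophotometry, with a stated time of 5 min; on this read-out higher numbers stand for weaker inhibition and lower numbers for stronger inhibition:
compound 1 `CC(=O)COc1cc(=O)oc2cc(OCc3cccc(Cl)c3)ccc12` gives 26.9 nM;
compound 2 `O=c1cc(Cl)c2ccc(OCc3cccc(Cl)c3)cc2o1` gives 20.9 nM;
compound 3 `CCOC(=O)Nc1cc(=O)oc2cc(OCc3cccc(Cl)c3)ccc12` gives 589 nM.

Compound 3 stands with the highest number of the three, reached by two large steps beyond the scatter: a 22-fold higher number from compound 1 to compound 3 (1.34 log units; beyond the scatter) and a 28-fold higher number from compound 2 to compound 3 (1.45 log units; beyond the scatter). Compound 4 `O=c1cc(Nc2ccccc2)c2ccc(OCc3cccc(Cl)c3)cc2o1` differs from compound 3 by phenyl in place of ethoxycarbonyl on a nitrogen on an aromatic ring. Going by the values given here, no measured step involves an anilino group, so this change can only be judged indirectly. The two steps onto compound 3 show that bringing in the (ethoxycarbonyl)amino group raised the number sharply, and compound 4 removes the ethoxycarbonyl part while keeping the nitrogen. A move back toward the lower numbers of compound 1 and compound 2 is therefore expected, of uncertain size. For compound 4 the expected value is 100 nM, between 20 nM and 500 nM, an expected step of a 5.9-fold lower number from compound 3 to compound 4 (0.77 log units; beyond the scatter).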

Compound 4, half-maximal inhibitory concentration: 9770 nM
For compound 4 the middle estimate is 98-fold (1.99 log units) below the measured one; the whole stated range lies below it.
By their numbers in this assay, from the lowest: compounds 2 and 1 (each within the scatter of the next); then compound 3; then compound 4.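

In this assay taking away the ethoxycarbonyl did not restore the low numbers: phenyl on this nitrogen gives a 17-fold higher number from compound 3 to compound 4 (1.22 log units; beyond the scatter) and so what the nitrogen carries matters, not only the nitrogen itself. Set against the chloro and 2-oxopropoxy groups, the anilino group stands much further off, with a 470-fold higher number from compound 2 to compound 4 (2.67 log units; beyond the scatter) and a 360-fold higher number from compound 1 to compound 4 (2.56 log units; beyond the scatter) on this aromatic carbon. Nothing measured here explains the rise. Still open, from the compounds shown here alone, is where a plain amino group or an acetyl on this nitrogen would fall. Also open, going by these compounds, is whether a benzyl group on the nitrogen would bring the number back down.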